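The source may report more compounds than this note shows. Statements on the series, on what has been measured and on what is new or still open speak of the compounds shown alone.

Compound 1 `COc1ccc(/C=C(/Sc2ccc(C)cc2)C(=O)c2ccc(Cl)cc2)cc1O` gives 1000 nM in a functional assay on DU-145 cells (Homo sapiens) for inhibition, read by trypan blue exclusion, with a stated time of 96 h (on this read-out lower numbers stand for stronger inhibition of growth and higher numbers for weaker inhibition of growth), the lowest of the two numbers in hand. Compound 2 `O=C(/C(=C\c1ccc(F)cc1C(F)(F)F)[S+]([O-])Cc1ccc(Cl)cc1)c1ccc(Cl)cc1` gives 50000 nM in this assay, a gap from compound 1 that lies beyond the scatter. Compound 3 `Cc1ccc(S/C(=C/c2c(O)cc(O)cc2O)C(=O)c2ccc(Cl)cc2)cc1` differs from compound 1 in one place: 2,4,6-trihydroxyphenyl in place of 3-hydroxy-4-methoxyphenyl on a double-bonded chain carbon bound to a double-bonded chain carbon. Going by the values given here, no measured pair shows this change, so only an expectation can be offered. Compound 3 is expected to carry a modest step toward weaker inhibition of growth, a 3.0-fold higher number from compound 1 to compound 3 (0.48 log units; beyond the scatter), of a size near the edge of the scatter. Compound 3 is therefore estimated at 3000 nM, with a range from 700 nM to 15000 nM.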

Compound 3, concentration for 50% growth inhibition: > 100000 nM
Compound 3 gave a limit, no number (the forecaster's own chance of this, stated with the estimate: 10%); middle value at least 33-fold (1.52 log units) from the limit.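

Compound 3 gives > 100000 nM in this assay, a limit of the assay and not a number. Replacing 3-hydroxy-4-methoxyphenyl with 2,4,6-trihydroxyphenyl on a double-bonded chain carbon bound to a double-bonded chain carbon brings an at least 100-fold higher number from compound 1 to compound 3 (2.00 log units; beyond the scatter). Going by these compounds alone, this is the first single-place comparison, and it shows that growth inhibition here depends strongly on which aryl group sits at this place.

The compounds shown do not separate the loss of the methoxy group from the gain of hydroxyl groups. On these data alone, how a phenyl ring carrying an amine or a carboxylic acid would behave at this place also stays open.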